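The source may hold more compounds than are shown below. What is called first, only, known or untested is meant among the compounds shown, and "the series" means these compounds.

Values so far in a physicochemical assay for solubility, read by HPLC, in phosphate buffer, measured as kinetic solubility, with a stated time of 1 h, at pH 7.4, tested at 250 uM; a lower number here means a less soluble compound, a higher number a more soluble compound
- compound 1 `CN1CCC(c2ccc3c(c2)oc(=O)n3C(=O)NCCCCc2ccc(F)cc2)CC1` gives 22000 nM
- compound 2 `CN1CCN(c2ccc3c(c2)oc(=O)n3C(=O)NCCCCc2ccccc2)C(=O)C1` gives 20000 nM

For the measured compounds named here, compound 2 at 20000 nM and compound 1 at 22000 nM lie within the usual scatter of each other, so compound 2 stands level with the only other measured compound. Going by the values given here, the two differ in more than one place, and they offer no measured step for the change considered here.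

The change to compound 3 `CN1CCN(c2ccc3c(c2)oc(=O)n3C(=O)NCCCCc2ccccc2)CC1=O` is 4-methyl-3-oxopiperazin-1-yl in place of 4-methyl-2-oxopiperazin-1-yl on an aromatic carbon and it leaves the rest of compound 2 untouched. The two have the same atoms, joined differently, and the swap sits on the same aromatic carbon of the shared core.

Among the compounds with values here, with no matched pair available, the expectation for this assay rests on compound 2 at 20000 nM and on the closeness of the two measured values. No step beyond the scatter is expected, and the estimated 1.3-fold lower number from compound 2 to compound 3 (0.10 log units; within the scatter) is small. For compound 3 the estimated value is 16000 nM with an expected range of 7000 nM to 40000 nM until the measurement is in.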

Compound 3, solubility: < 1000 nM
Compound 3: only a limit was reported; the forecaster's own chance of this, stated with the estimate: 3%; middle value at least 16-fold (1.20 log units) away from the limit.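

In this assay, for the compounds shown here, 4-methyl-3-oxopiperazin-1-yl in place of 4-methyl-2-oxopiperazin-1-yl on the same aromatic carbon gives the only single-place step so far: an at least 20-fold lower number from compound 2 to compound 3 (1.30 log units; beyond the scatter). The two groups match in heavy atoms, ring size, hetero atoms, hydrogen-bond donors and acceptors, and net charge, so none of these counts separates compound 2 from compound 3, and only the way the atoms are joined within the ring differs. Compound 3 is reported only as a limit, so the step gives a minimum size and not an exact one: the limit of < 1000 nM in this assay, at which 1 of the 3 values shown sits.

A 4-methylpiperazin-1-yl group, with no carbonyl in the ring, on this aromatic carbon would show which of the two oxopiperazinyl groups departs further from the parent ring in this assay. Going by these compounds, it also remains open how far the value of compound 3 lies past the limit, and whether the same swap gives a step of similar size with a 4-fluorophenyl group at the end of the butyl chain, as in compound 1.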